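This account rests on a few compounds, and the source may have more. Where it says the series, first, only, none or still open, it means among the compounds named here.

Measured compounds:
Compound 1 `CCSc1nnc(COc2cc(C)c3c(C)cc(=O)oc3c2)o1`: > 100000 nM
Compound 2 `Cc1cc(OCc2nnc(SCc3ccc(Cl)cc3Cl)o2)cc2oc(=O)cc(C)c12`: > 100000 nM

Both numbers come from a functional assay on MDA-MB-231 cells (Homo sapiens) for antiproliferative activity, read by MTT assay, with a stated time of 24 h; on this read-out lower numbers stand for stronger inhibition and higher numbers for weaker inhibition. In it compound 1 gives > 100000 nM, which is a limit of the assay and not a number. Compound 2 in turn gives > 100000 nM, again a limit and not a number. For the measured compounds named here, the single step between the two, a step that the two limits leave unreadable from compound 1 to compound 2, therefore cannot be read in size or direction, as the limit of > 100000 nM in this assay, at which 2 of the 2 values shown sit, shows. Compound 2 thus stands at the limit, and nothing beyond that is known about it.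

Compound 3 `CCS(=O)(=O)c1nnc(COc2cc(C)c3c(C)cc(=O)oc3c2)o1` differs from compound 2 in one place: ethylsulfonyl in place of (2,4-dichlorobenzyl)sulfanyl on an aromatic carbon. Going by the values given here, no measured step concerns this exchange; the only step available, a step that the two limits leave unreadable from compound 1 to compound 2, is unreadable, so nothing supports an expectation of a gain or a loss beyond the scatter. Compound 3 is therefore expected to sit near 150000 nM, with a range from 30000 nM to 600000 nM, and most likely to be reported once more as a limit rather than a number. That estimate means an expected step that the limit leaves unreadable from compound 2 to compound 3, which is a guess and not a measured value.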

Compound 3, half-maximal inhibitory concentration: > 100000 nM
Compound 3 was reported as a limit; the forecaster's own chance of this, stated with the estimate: 70%; the middle value lies beyond the limit too.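

In this assay compound 3 gives > 100000 nM, which is a limit of the assay and not a number. The steps linking compound 3 to compound 1 and compound 2 therefore cannot be read in size or direction: the limit of > 100000 nM in this assay, at which 3 of the 3 values shown sit. Left open is whether the group exchanged among these three compounds has any effect on the read-out in this assay.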